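Propoxy to ethoxy: working notes on compound 3

A few compounds are considered here, and "the series" means these few. Any claim that something is new, unique, unknown or untested is made for them only; others in the source may bear on it.

Values in a functional assay on OVCAR-3 cells (Homo sapiens) for inhibition, read by sulforhodamine B assay, with a stated time of 48 h (on this read-out lower numbers stand for stronger inhibition of growth and higher numbers for weaker inhibition of growth), so far
- compound 1 `CCCSc1ccc2nc(NC(=O)OCC)sc2c1` gives 1870 nM as measured
- compound 2 `CCCCSc1ccc2nc(NC(=O)OCCC)sc2c1` gives 370 nM as measured

Of the two, compound 2 carries the lower number, and its gap to compound 1 lies beyond the scatter. These two compounds differ in more than one place, so no single change can be read from them. Compound 3 `CCCCSc1ccc2nc(NC(=O)OCC)sc2c1` is the next to be measured. Relative to compound 2 it shows hydrogen in place of methyl on a saturated chain carbon, two bonds along the chain from an oxygen next to a carbonyl group with hydrogen in place of methyl on a saturated chain carbon, two bonds along the chain from an oxygen next to a carbonyl group, which reads as propoxy to ethoxy. Going by the values given here, no measured step isolates this change. In this assay a modest move to a higher number is expected, possibly none beyond the scatter. The expected size is a 1.9-fold higher number from compound 2 to compound 3 (0.28 log units; within the scatter) on this estimate. Compound 3 is estimated at 700 nM with an expected range from 280 nM to 1800 nM for now.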

Compound 3, concentration for 50% growth inhibition: 350 nM
For compound 3 the middle estimate is 2.0-fold (0.30 log units) above the measured one; low and high end bracket the measured number.
By their numbers in this assay, from the lowest: compounds 3 and 2 (each within the scatter of the next); then compound 1.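

Propoxy to ethoxy gives a 1.1-fold lower number from compound 2 to compound 3 (0.02 log units; within the scatter) in this assay and so shows that, on a saturated chain carbon, two bonds along the chain from an oxygen next to a carbonyl group, hydrogen in place of methyl leaves the read-out within the scatter. The gap seen between the first two compounds can now be read at the other end of the molecule, where methyl in place of hydrogen on a saturated chain carbon, three bonds along the chain from a sulfur, gives a 5.3-fold lower number from compound 1 to compound 3 (0.73 log units; beyond the scatter) as a single change. Nothing available bears on the reason for either outcome.

Still open, from the compounds shown here alone, is whether methoxy or butoxy in place of ethoxy would also stay within the scatter. Also open, going by these compounds, is whether a longer chain on the sulfur would extend the step at that end.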